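The source may report more compounds than this note shows. Statements on the series, on what has been measured and on what is new or still open speak of the compounds shown alone.

Compound 1 `CCCCCCCCc1cn([C@H]2C[C@H](O)[C@@H](CO)O2)c(=O)[nH]c1=O`: 140 ug/mL
Compound 2 `CCc1cn([C@H]2C[C@@H]3OP(=O)(O)OC[C@H]3O2)c(=O)[nH]c1=O`: > 500 ug/mL

In a functional assay on Raji cells (Homo sapiens) (a lower number here means a stronger inhibitor, a higher number a weaker inhibitor), compound 2 sits at the limit of > 500 ug/mL in this assay, at which 1 of the 2 values shown sits, which is a limit of the assay and not a number. Among the measured compounds shown here, compound 1, carrying the longer chain on a different sugar, gives 140 ug/mL in this assay; no step between these two compounds is known. Compound 3 `CCCCCCCCc1cn([C@H]2C[C@@H]3OP(=O)(O)OC[C@H]3O2)c(=O)[nH]c1=O` is reached from compound 2 by hexyl in place of hydrogen on a saturated chain carbon, two bonds along the chain from an aromatic carbon. The step from compound 2 to compound 3 is expected to go toward stronger inhibition, beyond the usual scatter, an at least 2.0-fold lower number from compound 2 to compound 3 (0.30 log units; that floor lies within the scatter), since compound 1 with the same octyl chain gives 140 ug/mL. Compound 3 is therefore estimated at 250 ug/mL, with a range from 80 ug/mL to 700 ug/mL.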

Compound 3, concentration for 50% inhibition: 184 ug/mL
Beside the measured number, compound 3's estimate is 1.4-fold (0.13 log units) above it; the range from low to high includes it.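

In this assay compound 2 gives > 500 ug/mL, which is a limit of the assay and not a number. With the core held constant, hexyl in place of hydrogen on a saturated chain carbon, two bonds along the chain from an aromatic carbon, gives an at least 2.7-fold lower number from compound 2 to compound 3 (0.43 log units; beyond the scatter). Among the compounds shown here, this is the first direct evidence that lengthening the chain at this position strengthens inhibition, though only the minimum size of the step can be read. As far as these compounds go, what a longer chain or a carboxylic acid in place of the octyl chain would give in this assay stays open.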